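Lengthening a Short Side Chain on a Toll-Like Receptor 8 Agonist

This account rests on a few compounds, and the source may have more. Where it says the series, first, only, none or still open, it means among the compounds named here.

Compound 1 `CCCCNc1nc(N)nc(C)c1CC` carries a short ethyl chain on its shared core. In an assay on HEK293 cells for agonist activity at Toll-like receptor 8 (Homo sapiens), read by spectrophotometry (a higher number here means that more compound is needed for the effect, a lower number that less compound is needed), compound 1 gives 1660 nM, the highest of the three numbers shown. Compound 2 `CCCCNc1nc(N)nc(C)c1CCCN1C(=O)c2ccccc2C1=O` gives 453 nM in this assay, and compound 3 `CCCCNc1nc(N)nc(C)c1CCCN1Cc2ccccc2C1` gives 29 nM; both lie below compound 1 by more than the usual scatter, so both need less compound for the effect. Compound 4 `CCCCCc1c(C)nc(N)nc1NCCCC` differs from compound 1 by propyl in place of hydrogen on a saturated chain carbon, two bonds along the chain from an aromatic carbon. Compound 2 and compound 3, each with a longer chain at this point, gave lower numbers than compound 1. On that basis a downward step is expected, estimated at a 4.7-fold lower number from compound 1 to compound 4 (0.68 log units; beyond the scatter). Compound 4 is therefore expected to give about 350 nM in this assay, within a range from 90 nM to 1400 nM.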

Compound 4, half-maximal effective concentration: 1220 nM
The estimate for compound 4 lay 3.5-fold (0.54 log units) below the measured number; low and high end bracket the measured number.
By their numbers in this assay, from the lowest: compound 3; then compound 2; then compounds 4 and 1 (each within the scatter of the next).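

Propyl in place of hydrogen on this saturated chain carbon, two bonds along the chain from an aromatic carbon, gives a 1.4-fold lower number from compound 1 to compound 4 (0.13 log units; within the scatter) in this assay. Going from ethyl to pentyl at this point therefore gives a number that cannot be told apart from that of compound 1, so added plain chain length alone is not enough for a clear step here. No evidence at hand bears on this result.

Open, on these data alone, is how a longer hexyl chain would read here. Also open, as far as these compounds go, is what a pentyl chain ending in a hydroxyl group or a carboxylic acid would give.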